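Quinoline amides: replacing dipropylamino with a primary amino group

The source may report more compounds than this note shows. Statements on the series, on what has been measured and on what is new or still open speak of the compounds shown alone.

Measured compounds:
Compound 1 `O=C(CCc1ccc(C(F)(F)F)cc1)Nc1ccc2nc(N3CCC3)ccc2c1` gives 4 nM in an assay on isolated protein for displacement of a labelled ligand from melanin-concentrating hormone receptor 1 (Homo sapiens); on this read-out lower numbers stand for stronger inhibition and higher numbers for weaker inhibition.
Compound 2 `CCCN(CCC)c1ccc2cc(NC(=O)CCc3ccc(C(F)(F)F)cc3)ccc2n1` gives 490 nM in this assay.

For the measured compounds named here, compound 2 holds the higher of the two numbers measured so far; the only neighbour is compound 1, with a much lower number. Going by the values given here, the one step known is a 120-fold higher number from compound 1 to compound 2 (2.09 log units; beyond the scatter), so the azetidin-1-yl group and the dipropylamino group behave very differently at the same position.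

Compound 3 `Nc1ccc2cc(NC(=O)CCc3ccc(C(F)(F)F)cc3)ccc2n1` has not been measured. It differs from compound 2 by amino in place of dipropylamino on an aromatic carbon, an amino in place of dipropylamino on an aromatic carbon, next to the ring nitrogen.

Among the compounds with values here, the step from compound 1 to compound 2 is the only guide, and it concerns a different pair of groups, so it does not fix the direction for compound 3. Since the dipropylamino group gave the highest number seen, a smaller amino group is expected to move back towards compound 1, though how far is uncertain; the expected step is a 4.9-fold lower number from compound 2 to compound 3 (0.69 log units; beyond the scatter). Compound 3 is therefore estimated at 100 nM, with a range from 15 nM to 800 nM.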

Compound 3, half-maximal inhibitory concentration: 240 nM
Beside the measured number, compound 3's estimate is 2.4-fold (0.38 log units) below it; the range from low to high includes it.
By their numbers in this assay, from the lowest: compound 1; then compound 3; then compound 2.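

In this assay, going from the dipropylamino group to the amino group strips away six carbon atoms yet gives only a 2.0-fold lower number from compound 2 to compound 3 (0.31 log units; beyond the scatter), a modest step. The other comparison is large, with a 60-fold higher number from compound 1 to compound 3 (1.78 log units; beyond the scatter), so the smallest group tested here does not bring back the low number of compound 1. Among these three compounds, a smaller group at this position is therefore not enough on its own: the amino and dipropylamino groups, neither of which has a ring, both give much higher numbers than azetidin-1-yl, the only ring-bearing group of the three.

Three compounds cannot show whether the ring of azetidin-1-yl is what matters, and a pyrrolidine ring, a dimethylamino group or an open-chain methylamino group at the same place would help separate the ring from the number of carbon atoms. The data shown offer no measurement that explains why these groups differ.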